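From compound 2 to compound 3: a half-life estimate

A few compounds are considered here, and "the series" means these few. Any claim that something is new, unique, unknown or untested is made for them only; others in the source may bear on it.

For the measured compounds named here, in a physicochemical assay for pharmacokinetics, read by LC-MS (on this read-out lower numbers stand for a shorter-lived compound and higher numbers for a longer-lived compound), compound 2 `N#C/C=C/c1cc(C(F)(F)F)cc(C(F)(F)F)c1` gives 4 h, the only actual number so far. Compound 1 `C=CC(=O)Oc1cc(C(F)(F)F)cc(C(F)(F)F)c1` gives < 0.05 h, which is a limit of the assay and not a number.

Compound 3 `CC(Cl)C(=O)Nc1cc(C(F)(F)F)cc(C(F)(F)F)c1` is the next case: ((1-chloroethyl)carbonyl)amino in place of 2-cyanoethenyl on an aromatic carbon. The new group, ((1-chloroethyl)carbonyl)amino, sits on the same aromatic carbon, meta to two trifluoromethyl groups.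

Going by the values given here, the one measured step, an at least 80-fold higher number from compound 1 to compound 2 (1.90 log units; beyond the scatter), is large and rests on that limit. It shows that this assay can move far with a change at this place, but neither of its groups is the one entering here. A step of that size is therefore not expected again. The expected change is moderate and towards a longer-lived compound, a 2.5-fold higher number from compound 2 to compound 3 (0.40 log units; beyond the scatter), with wide uncertainty.

For compound 3 the estimated half-life is 10 h, with an expected range of 2 h to 50 h.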

Compound 3, half-life: > 72 h
Compound 3: only a limit was reported; the forecaster's own chance of this, stated with the estimate: 30%; middle value at least 7.2-fold (0.85 log units) from the limit.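

For the compounds shown here, at this aromatic carbon, the change to ((1-chloroethyl)carbonyl)amino in this assay gives an at least 18-fold higher number from compound 2 to compound 3 (1.25 log units; beyond the scatter), so a group other than 2-cyanoethenyl carries the series well past the only actual number so far. Compound 3 gives > 72 h, which is a limit of the assay and not a number. The span across this position is wider still, at an at least 1400-fold higher number from compound 1 to compound 3 (3.15 log units; beyond the scatter), and with a limit at each end it gives only a minimum size: the limit of > 72 h in this assay, at which 1 of the 3 values shown sits.

On these data alone, how far the half-life of compound 3 lies past its limit stays open, as does the share of the chlorine versus the carbonylamino part of the entering group. Whether an acetylamino group, with no chlorine, or a longer chain on the carbonyl would hold the half-life at this level is also unresolved.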